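From thiophen-3-yl to 3-chlorophenyl: working notes

The source may hold more compounds than are shown below. What is called first, only, known or untested is meant among the compounds shown, and "the series" means these compounds.

Measured so far in an in vivo ADME assay on the whole organism for pharmacokinetics, with Rattus norvegicus as the target; on this read-out lower numbers stand for narrower distribution and higher numbers for wider distribution into tissues:
- compound 1 `O=C(Nc1cccnc1-c1ccsc1)N1CCN2C(=O)N([C@H]3C[C@@H]3c3ccccc3)C(=O)[C@@H]2C1` gives 10 L/kg here
- compound 2 `CN(C)C(=O)c1cc(Cl)c(NC(=O)N2CCN3C(=O)N([C@H]4C[C@@H]4c4ccccc4)C(=O)[C@@H]3C2)c(Cl)c1` gives 2.1 L/kg here

Compound 1 holds the higher of the two numbers, and compound 2 is its nearest neighbour, with a gap beyond the usual scatter. Among the compounds with values here, these two compounds differ in more than one place, so the data hold no single-change step to serve as a guide.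

Compound 3 `O=C(Nc1cccnc1-c1cccc(Cl)c1)N1CCN2C(=O)N([C@H]3C[C@@H]3c3ccccc3)C(=O)[C@@H]2C1` has not yet been measured. It differs from compound 1 at one place (3-chlorophenyl in place of thiophen-3-yl on an aromatic carbon), with 3-chlorophenyl in place of thiophen-3-yl on an aromatic carbon, next to the ring nitrogen and ortho to a large group. The rest of the structure is unchanged, and one aromatic ring replaces another, so no step beyond the scatter is expected in this assay, in either direction. The expected change is small (a 1.3-fold lower number from compound 1 to compound 3 (0.10 log units; within the scatter)) and is an estimate only. With so few values, the range is kept wide. For compound 3 the estimated value is 8 L/kg, with an expected range from 3.5 L/kg to 18 L/kg in this read-out.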

Compound 3, volume of distribution at steady state: 4.1 L/kg
Compound 3: the middle estimate sits 2.0-fold (0.29 log units) above what was measured, within the range that was stated.
By their numbers in this assay, from the lowest: compounds 2 and 3 (each within the scatter of the next); then compound 1.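

Within the data shown here, at this position, on an aromatic carbon next to the ring nitrogen and ortho to a large group, 3-chlorophenyl in place of thiophen-3-yl gives the first single-change step in this assay: a 2.4-fold lower number from compound 1 to compound 3 (0.39 log units; beyond the scatter). The step shows that this read-out responds to an exchange of one aromatic ring for another at this place, even with the rest of the structure unchanged, although the size of the step remains modest. No measurement at hand bears on what lies behind this step.

The change replaces a five-membered ring holding sulfur with a six-membered ring of carbon only and brings in chlorine in the same move, so the compounds shown cannot separate the part played by the ring from the part played by the chlorine; unsubstituted phenyl at this place would divide the step into those two parts. Also open, on these data alone, is how this assay responds at this position to a ring with a further nitrogen, such as pyridin-3-yl, or to a phenyl ring carrying an amine or a carboxylic acid.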